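Methoxy in place of methyl: solubility notes on the series

The compounds below may be only part of what the source reports. "The series", "measured", "known", "first", "only" and "open" are said of these compounds alone.

The series shares one core; compound 1 is `CC(C)Nc1nc(NCc2ccco2)c2cc(Cl)ccc2n1` and compound 2 is `Cc1ccc2nc(NC(C)C)nc(NCc3ccco3)c2c1`. In a physicochemical assay for solubility, at pH 7.4 (on this read-out lower numbers stand for lower solubility and higher numbers for higher solubility), compound 1 gives <= 20000 nM, which is a limit of the assay and not a number. In this assay compound 2 gives <= 20000 nM, again a limit and not a number. The step from compound 1 to compound 2, methyl in place of chloro on an aromatic carbon, is a step that the two limits leave unreadable from compound 1 to compound 2. Both values sit at the same limit (the limit of <= 20000 nM in this assay, at which 2 of the 2 values shown sit), so no readable step exists and compound 2 stands only at that limit.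

Compound 3 is `COc1ccc2nc(NC(C)C)nc(NCc3ccco3)c2c1`. It differs from compound 2 by methoxy in place of methyl on an aromatic carbon. For the measured compounds named here, no measured step bears on this change; the only measured step is unreadable. With nothing to set a size or direction, the expected step from compound 2 to compound 3 in this assay is a step that the limit leaves unreadable from compound 2 to compound 3, small or none. Compound 3 is therefore expected at 12000 nM, ranging 2000 nM to 30000 nM, with a good chance that only the same limit is again reported.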

Compound 3, solubility: >= 30000 nM
Compound 3: no number, only a limit; the forecaster's own chance of this, stated with the estimate: 65%; at least 2.5-fold (0.39 log units) between middle value and limit.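

At this aromatic carbon the read-out now has a direction, which the earlier pair could not give: methoxy in place of methyl gives an at least 1.5-fold higher number from compound 2 to compound 3 (0.17 log units; that floor lies within the scatter) and methoxy in place of chloro gives an at least 1.5-fold higher number from compound 1 to compound 3 (0.17 log units; that floor lies within the scatter). In this assay compound 3 gives >= 30000 nM and that is a limit and not a number. For the compounds shown here, each step therefore has only a floor, and the separation from the earlier compounds rests on a different limit: the limit of >= 30000 nM in this assay, at which 1 of the 3 values shown sits.

As far as these compounds go, the true size of both steps remains open, and the step between compound 1 and compound 2 cannot be read. The compounds shown also do not tell whether the oxygen of methoxy matters or the extra heavy atom alone, which an ethyl group would help to separate, nor how an amine or a carboxylic acid on this carbon would read.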